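The compounds below may be only part of what the source reports. "The series", "measured", "known", "first", "only" and "open" are said of these compounds alone.

Of the compounds shown here, three share one core and have been tested in a functional assay on NCI-H226 cells (Homo sapiens) for inhibition, read by sulforhodamine B assay, with a stated time of 48 h; on this read-out lower numbers stand for higher toxicity in this test and higher numbers for lower toxicity in this test. Compound 1 `O=C(Nc1cccc(-n2cc(-c3ccncc3)c(-c3ccc(Cl)c(O)c3)n2)c1)Nc1cc(C(F)(F)F)cc(C(F)(F)F)c1` gives 37600 nM. For compound 2 `COc1cc(-c2nn(-c3cccc(NC(=O)Nc4cccc(C(F)(F)F)c4)c3)cc2-c2ccncc2)ccc1Cl` the assay reports only a limit, > 50000 nM, so its toxicity is not pinned to a number. For compound 3 `COc1cc(-c2nn(-c3cccc(NC(=O)Nc4ccc(Cl)c(C(F)(F)F)c4)c3)cc2-c2ccncc2)ccc1Cl` the result is likewise a limit, > 32500 nM. The one single-point change among these, a step that the two limits leave unreadable from compound 2 to compound 3, connects two limits and so tells nothing about size or direction.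

Compound 4 `COc1cc(-c2nn(-c3cccc(NC(=O)Nc4cc(C(F)(F)F)cc(C(F)(F)F)c4)c3)cc2-c2ccncc2)ccc1Cl` differs from compound 2 by trifluoromethyl in place of hydrogen on an aromatic carbon. For the measured compounds named here, no measured step involves this exact change, so the expectation rests on what the numbers show: compound 1 carries the same bis(trifluoromethyl) urea as compound 4 and sits at a weak value, while compound 2 and compound 3 sit at limits, as the lines the limit of > 50000 nM in this assay, at which 1 of the 3 values shown sits, and the limit of > 32500 nM in this assay, at which 1 of the 3 values shown sits, record. Nothing here points to a large gain in toxicity, so the step from compound 2 to compound 4 is expected to stay near the scatter, as an at least 1.2-fold lower number from compound 2 to compound 4 (0.09 log units; that floor lies within the scatter), with a fair chance that only a limit is returned again. Compound 4 is therefore estimated at 40000 nM, within 15000 nM to 100000 nM, in this assay.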

Compound 4, concentration lethal to 50% of the cells: > 50000 nM
Compound 4 ended at the assay's limit (the forecaster's own chance of this, stated with the estimate: 55%); middle value at least 1.2-fold (0.09 log units) from the limit.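

In this assay compound 4 returns only a limit of the assay, the second compound shown to sit at this same limit: the limit of > 50000 nM in this assay, at which 2 of the 4 values shown sit. The steps that add trifluoromethyl or chloro to the aromatic ring each join two limits, so neither can be read for size or direction. For the compounds shown here, the new information comes from the change of hydrogen to methyl on an oxygen on an aromatic ring, which gives the first readable step in this set, an at least 1.3-fold higher number from compound 1 to compound 4 (0.12 log units; that floor lies within the scatter), so this pair shows a direction but cannot show that the change has an effect larger than repeat measurements would produce.

Compound 1 gives 37600 nM and is the only compound shown with an exact number, so how far the true values of the other compounds lie from it remains unknown, and the effect of hydrogen or methyl on that oxygen rests on this single pair. Going by these compounds, how a longer chain on that oxygen, or an amine or a carboxylic acid at the place taken by trifluoromethyl, would read in this assay also stays open.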